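This account rests on a few compounds, and the source may have more. Where it says the series, first, only, none or still open, it means among the compounds named here.

Working notes on a small sulfonamide series.

Compound 1 `COc1cc(N(Cc2nc3ccccc3[nH]2)S(=O)(=O)c2ccccc2)cc(OC)c1OC` is the reference. In a functional assay on MGC-803 cells (Homo sapiens) for inhibition, read by MTT assay, with a stated time of 48 h (on this read-out lower numbers stand for stronger inhibition and higher numbers for weaker inhibition), compound 1 gives 12400 nM. Compound 2 `COc1cc(N(Cc2nc3ccccc3[nH]2)S(=O)(=O)c2ccccc2Cl)cc(OC)c1OC` carries one further group; in this assay compound 2 gives 19100 nM. Compound 3 `Cc1ccc(S(=O)(=O)N(Cc2nc3ccccc3[nH]2)c2ccc(Cl)cc2)cc1` is built on a different core, and the difference between the core of compound 3 and that of compound 2 is not broken down here; in this assay compound 3 gives 24800 nM. The three values lie within the scatter of one another, so no ordering among compounds 1, 2 and 3 is read from them.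

One change is seen twice in the set. From compound 2 to compound 1 it is hydrogen in place of chloro on an aromatic carbon, and the step it made is a 1.5-fold lower number from compound 2 to compound 1 (0.19 log units; within the scatter). From compound 3 to compound 4 `Cc1ccc(S(=O)(=O)N(Cc2nc3ccccc3[nH]2)c2ccccc2)cc1` the change is hydrogen in place of chloro on an aromatic carbon. The two are the same kind of change, not the same: in the first the place is ortho to a large group, in the second it is para to a large group, and the cores differ.

For compound 4 the expectation rests on the step from compound 2 to compound 1, a 1.5-fold lower number from compound 2 to compound 1 (0.19 log units; within the scatter), applied to the starting point of compound 3, which gives 24800 nM in this assay. The step from compound 3 to compound 4 is therefore expected to be a 1.4-fold lower number from compound 3 to compound 4 (0.14 log units; within the scatter), a step within the scatter. Compound 4 is estimated at 18000 nM in this assay, with a range from 9000 nM to 40000 nM; the measurement will show whether the para placement behaves like the ortho one.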

Compound 4, half-maximal inhibitory concentration: 45200 nM
For compound 4 the middle estimate is 2.5-fold (0.40 log units) below the measured one; measured number outside the range, above it.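

In this assay, the replacement of chloro by hydrogen, here 4-chlorophenyl to phenyl, gives a 1.8-fold higher number from compound 3 to compound 4 (0.26 log units; within the scatter), and this step does not match the earlier one on the other core: the same change on two cores in this assay, a 1.5-fold lower number (0.19 log units; within the scatter) from compound 2 to compound 1 and a 1.8-fold higher number (0.26 log units; within the scatter) from compound 3 to compound 4, 2.8-fold (0.45 log units) apart, beyond the scatter of two such steps. Taken singly, each of the two steps lies within the scatter, so neither one shows that this change alone moves the number on its own core; only the gap between them stands out, and it rests on a single pair of compounds per core. The two pairs differ both in the core and in the place of the chloro, so the gap cannot be assigned to either one, and the step seen on the core of compound 1 gives no reliable estimate for the same change on the core of compound 3, though two pairs establish no general rule for the series.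

The compounds shown leave open whether the gap follows the core or the place of the chloro, a question that needs the chloro at the same place on both cores. Also open, as far as these compounds go, is how other groups at that place, such as an amine or a carboxylic acid, would behave on either core.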